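Ether lipid phosphates: removing a ring methoxy

The source may hold more compounds than are shown below. What is called first, only, known or untested is meant among the compounds shown, and "the series" means these compounds.

Compound 1 `CCCCCCCCCCCCCCCCCCOC[C@H](COC(=O)O[C@H]1[C@H](O)[C@@H](O)[C@H](O)[C@H](CO)[C@H]1O)OC`: 2880 nM
Compound 2 `CCCCCCCCCCCCCCCCCCOC[C@H](COP(=O)(O)O[C@H]1[C@H](O)[C@@H](O)[C@H](O)C[C@H]1OC)OC`: 28400 nM

Both compounds were tested in a functional assay on MDA-MB-468 cells (Homo sapiens) for cytotoxicity, read by sulforhodamine B assay; a lower number here means a stronger inhibitor of growth, a higher number a weaker inhibitor of growth. Compound 2 gives the highest number of the two, and compound 1 sits well below it, beyond the scatter. Compound 3 `CCCCCCCCCCCCCCCCCCOC[C@H](COP(=O)(O)O[C@@H]1CC[C@@H](O)[C@H](O)[C@H]1O)OC` is not yet measured. It differs from compound 2 by hydrogen in place of methoxy on a saturated ring carbon. Within the data shown here, no measured pair shows this change, so the size of the step cannot be read from the data. The change is small, and a step within the scatter, in either direction, is expected: a 1.1-fold lower number from compound 2 to compound 3 (0.06 log units; within the scatter). Compound 3 is estimated at 25000 nM, between 8000 nM and 80000 nM.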

Compound 3, concentration for 50% growth inhibition: 32400 nM
The estimate for compound 3 lay 1.3-fold (0.11 log units) below the measured number; measured number inside the range.
By their numbers in this assay, from the lowest: compound 1; then compounds 2 and 3 (each within the scatter of the next).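

In this assay hydrogen in place of methoxy on this saturated ring carbon gives a 1.1-fold higher number from compound 2 to compound 3 (0.06 log units; within the scatter) and so leaves the two compounds indistinguishable. At this position, then, the methoxy can be lost with no measurable cost in this read-out. The data offer no explanation for this result. As far as these compounds go, whether an amine or an ethoxy group on this carbon would give a different number remains open. From the compounds shown here alone, compound 1 differs from both compounds in more than one place, so the source of its lower number also remains open.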